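Methoxy additions at two sites in the series

A few compounds are considered here, and "the series" means these few. Any claim that something is new, unique, unknown or untested is made for them only; others in the source may bear on it.

Compound 1 `Cn1cc(C2CC(c3ccccc3)=NN2C(=O)c2cccnc2)c2ccccc21` gives in a functional assay on A549 cells (Homo sapiens) for inhibition, read by MTT assay, with a stated time of 48 h (a higher number here means a weaker inhibitor of growth, a lower number a stronger inhibitor of growth), only the limit > 10000 nM, not a number (the limit of > 10000 nM in this assay, at which 1 of the 3 values shown sits). Compound 2 `COc1ccc(C(=O)N2N=C(c3ccccc3)CC2c2cn(C)c3ccccc23)cn1` gives 3040 nM in this assay; the step of an at least 3.2-fold lower number from compound 1 to compound 2 (0.51 log units; beyond the scatter) goes with methoxy in place of hydrogen on an aromatic carbon. Compound 3 `COc1ccc(C2=NN(C(=O)c3cccnc3)C(c3cn(C)c4ccc(Br)cc34)C2)cc1OC` gives 2380 nM in this assay; the difference between the cores of compound 1 and compound 3 is not broken down here. Compound 4 `COc1cc(C2=NN(C(=O)c3cccnc3)C(c3cn(C)c4ccc(Br)cc34)C2)cc(OC)c1OC` differs from compound 3 by methoxy in place of hydrogen on an aromatic carbon. The two places differ: in the first the methoxy sits on a six-membered aromatic ring with 1 nitrogen, next to the ring nitrogen, para to a large group; in the second on a six-membered aromatic ring of carbon only, ortho to a methoxy group, meta to a large group, meta to a methoxy group. It is the same kind of change, not the same. For compound 4 a step of a 1.6-fold lower number from compound 3 to compound 4 (0.20 log units; within the scatter) is expected, smaller than the only measured case an at least 3.2-fold lower number from compound 1 to compound 2 (0.51 log units; beyond the scatter), which is a limit-bounded step at a different place. Compound 4 is estimated at 1500 nM, between 500 nM and 5000 nM.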

Compound 4, concentration for 50% growth inhibition: > 10000 nM
Compound 4 was reported as a limit; the forecaster's own chance of this, stated with the estimate: 5%; at least 6.6-fold (0.82 log units) between middle value and limit.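

Turning 3,4-dimethoxyphenyl into 3,4,5-trimethoxyphenyl gives an at least 4.2-fold higher number from compound 3 to compound 4 (0.62 log units; beyond the scatter), against the direction of the earlier methoxy step: the same change on two cores in this assay, an at least 3.2-fold lower number (0.51 log units; beyond the scatter) from compound 1 to compound 2 and an at least 4.2-fold higher number (0.62 log units; beyond the scatter) from compound 3 to compound 4, at least 13-fold (1.14 log units) apart, beyond the scatter of two such steps. Compound 4 gives > 10000 nM in this assay, a limit and not a number. A methoxy gain thus does not carry from one core to the other here, but with the two places being different, these compounds cannot tell whether the site or the rest of the core decides the outcome.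

The compounds shown leave open whether an amine or a hydroxyl at that same place would read like compound 3 or like compound 4. Also open, on these data alone, is whether the methoxy of compound 2 would give a gain on the core of compound 3.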